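Two Fluorines in Place of Two Chlorines: An Expectation

The source may report more compounds than this note shows. Statements on the series, on what has been measured and on what is new or still open speak of the compounds shown alone.

Compound 1 `COc1ccc(-c2cc(/C=C/C(=O)c3ccc(N)cc3)[nH]n2)cc1`: 7090 nM
Compound 2 `COc1cc(-c2cc(/C=C/C(=O)c3ccc(Cl)c(Cl)c3)[nH]n2)cc(OC)c1OC`: > 100000 nM

In a functional assay on OVCAR-3 cells (Homo sapiens) for inhibition, read by sulforhodamine B assay, with a stated time of 48 h (a higher number here means that more compound is tolerated, a lower number that less compound is tolerated), compound 1 gives 7090 nM. Compound 2 is a different case: its reading, > 100000 nM, is a limit of the assay rather than a number. Compound 2 therefore sits at the limit of > 100000 nM in this assay, at which 1 of the 2 values shown sits, and nothing more precise is known about where it stands.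

Compound 3 `COc1cc(-c2cc(/C=C/C(=O)c3ccc(F)c(F)c3)[nH]n2)cc(OC)c1OC` differs from compound 2 in one place: 3,4-difluorophenyl in place of 3,4-dichlorophenyl on a carbonyl carbon. Going by the values given here, no measured pair of compounds shows what this exchange does, so the expectation rests on compound 2 alone. The step from compound 2 to compound 3 is expected to be small, none beyond the usual scatter, as a number no higher from compound 2 to compound 3 (the limit leaves the size open) expresses. In this assay compound 3 is therefore estimated to come out at 100000 nM, most likely again reported only as a limit, with a plausible range from 30000 nM to 300000 nM.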

Compound 3, concentration lethal to 50% of the cells: 43600 nM
Compound 3: the middle estimate sits 2.3-fold (0.36 log units) above what was measured; low and high end bracket the measured number.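

With compound 3, this place on the carbonyl carbon gets its first true number on this core: in this assay compound 3 gives 43600 nM, a reading inside the range of the assay. The exchange of 3,4-dichlorophenyl for 3,4-difluorophenyl therefore does leave a mark, with an at least 2.2-fold lower number from compound 2 to compound 3 (0.36 log units; beyond the scatter), meaning that the cells tolerate less of the compound. This step has a lower bound but no upper one, since the reading of compound 2 is only a limit: the limit of > 100000 nM in this assay, at which 1 of the 3 values shown sits.

As far as these compounds go, how large the step really is stays open, and so does whether it would hold on any other core. A single exchange also cannot show how a nitrile or a trifluoromethyl group at this place would compare with the two halogens.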